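Swapping an oxazole for an aminopyrimidine on a fused azaindazole

A few compounds are considered here, and "the series" means these few. Any claim that something is new, unique, unknown or untested is made for them only; others in the source may bear on it.

Of the compounds shown here, three have been tested in a functional assay (aorta) with Oryctolagus cuniculus as the target; on this read-out higher numbers stand for weaker inhibition and lower numbers for stronger inhibition. Compound 1 `OCc1ccc(-c2nn(Cc3ccc(F)cc3)c3ccccc23)o1` gives 19000 nM, compound 2 `Cc1coc(-c2nn(Cc3ccccc3F)c3ncccc23)n1` gives 1200 nM, and compound 3 `Nc1nc(-c2nn(Cc3ccccc3F)c3ncccc23)ncc1C1CCCC1` gives 904000 nM. Compound 2 thus stands lowest of the three, clearly below compound 1 and far below compound 3. Compound 4 `Cc1cc(N)nc(-c2nn(Cc3ccccc3F)c3ncccc23)n1` differs from compound 2 in one place: 4-amino-6-methylpyrimidin-2-yl in place of 4-methyl-1,3-oxazol-2-yl on an aromatic carbon. Among the measured compounds shown here, no measured pair shows this change directly. Compound 3, which also carries an aminopyrimidine on the shared core, gives 904000 nM, so a move toward higher numbers beyond the usual scatter is expected for compound 4. The estimated step is a 25-fold higher number from compound 2 to compound 4 (1.40 log units; beyond the scatter). Compound 4 is therefore expected to give about 30000 nM, within a range from 3000 nM to 300000 nM.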

Compound 4, half-maximal inhibitory concentration: 536000 nM
For compound 4 the middle estimate is 18-fold (1.25 log units) below the measured one, outside the stated range (above it).
By their numbers in this assay, from the lowest: compound 2; then compound 1; then compounds 4 and 3 (each within the scatter of the next).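

In this assay, among the compounds shown here, placing 4-amino-6-methylpyrimidin-2-yl instead of 4-methyl-1,3-oxazol-2-yl on this aromatic carbon gives a 450-fold higher number from compound 2 to compound 4 (2.65 log units; beyond the scatter), the first direct reading of this change. It shows that inhibition at this position depends strongly on which ring is attached, and that this exchange carries a large loss. No available evidence accounts for the size of this step.

The compounds shown do not separate the effect of the pyrimidine ring from that of its amine. Also open, as far as these compounds go, is how a 6-methylpyrimidin-2-yl group without the amine would read.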